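The compounds below may be only part of what the source reports. "The series", "measured", "known", "first", "only" and "open" are said of these compounds alone.

Compound 1 `COc1cccc(/C=C2\CCC/C(=C\c3cccc(Cl)c3)C2=O)c1OC` sets the starting point of this small series. In a functional assay on MCF7 cells (Homo sapiens) for cytotoxicity, read by MTT assay, with a stated time of 72 h (on this read-out lower numbers stand for stronger inhibition and higher numbers for weaker inhibition), compound 1 gives 12000 nM. Compound 2 `COc1cccc(/C=C2\CCC/C(=C\c3cccc(OC)c3OC)C2=O)c1` carries a single change, (methoxy in place of chloro on an aromatic carbon), and in this assay compound 2 gives 5900 nM; the step of a 2.0-fold lower number from compound 1 to compound 2 (0.31 log units; beyond the scatter). Compound 3 `COc1cccc(/C=C2\CCC/C(=C\c3ccc(O)c(Cl)c3)C2=O)c1OC` differs from compound 1 by hydroxy in place of hydrogen on an aromatic carbon, and in this assay compound 3 gives 16400 nM. The step of a 1.4-fold higher number from compound 1 to compound 3 (0.14 log units; within the scatter), while the step of a 2.8-fold higher number from compound 2 to compound 3 (0.44 log units; beyond the scatter).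

Compound 4 `COc1cc(/C=C2\CCC/C(=C\c3cccc(OC)c3OC)C2=O)ccc1O` has not been measured. It differs from compound 3 by methoxy in place of chloro on an aromatic carbon. Among the measured compounds shown here, this is the same kind of change as the one from compound 1 to compound 2, but not the same: in compound 3 the aromatic carbon that takes the change is ortho to a hydroxy group (1 heavy atom) and meta to a large group, whereas in compound 1 it is only meta to a large group. For the measured compounds named here, the earlier step of this kind, a 2.0-fold lower number from compound 1 to compound 2 (0.31 log units; beyond the scatter), is the sole guide available here, and the hydroxy group of compound 3 has no measured counterpart for this change. Going by the values given here, compound 4 is therefore expected to show a step of about a 2.1-fold lower number from compound 3 to compound 4 (0.31 log units; beyond the scatter) in this assay, resting on the single step from compound 1 to compound 2 and on the value of compound 3, 16400 nM. In this assay compound 4 is estimated at 8000 nM, with a likely range from 3500 nM to 18000 nM.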

Compound 4, half-maximal inhibitory concentration: 11600 nM
Beside the measured number, compound 4's estimate is 1.5-fold (0.16 log units) below it; the range from low to high includes it.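

In this assay, methoxy in place of chloro on an aromatic carbon gives a 1.4-fold lower number from compound 3 to compound 4 (0.15 log units; within the scatter), and this step does not differ beyond the scatter from the earlier step of the same kind: the same change on two cores in this assay, a 2.0-fold lower number (0.31 log units; beyond the scatter) from compound 1 to compound 2 and a 1.4-fold lower number (0.15 log units; within the scatter) from compound 3 to compound 4, 1.4-fold (0.16 log units) apart, within the scatter of two such steps Hydroxy in place of hydrogen on an aromatic carbon gives a 2.0-fold higher number from compound 2 to compound 4 (0.29 log units; within the scatter), and this step likewise agrees with its earlier counterpart: the same change on two cores in this assay, a 1.4-fold higher number (0.14 log units; within the scatter) from compound 1 to compound 3 and a 2.0-fold higher number (0.29 log units; within the scatter) from compound 2 to compound 4, 1.4-fold (0.16 log units) apart, within the scatter of two such steps Taken with a 1.0-fold lower number from compound 1 to compound 4 (0.01 log units; within the scatter), where 4-hydroxy-3-methoxyphenyl replaces 3-chlorophenyl, the four compounds are consistent with each change carrying from one core to the other, but each comparison rests on a single pair of steps, most of them within the scatter, so this does not establish a fixed size for either change or show that it would carry to any further core.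

The compounds shown leave open how an amine or a carboxylic acid in place of the hydroxy group would read in this assay. They also leave open whether a longer chain in place of the methoxy group would fit the same picture.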